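Replacing chloro with methyl on compound 2

The source may hold more compounds than are shown below. What is called first, only, known or untested is meant among the compounds shown, and "the series" means these compounds.

Of the compounds shown here, two have been measured in a physicochemical assay for lipophilicity; on this read-out lower numbers stand for lower lipophilicity and higher numbers for higher lipophilicity. Compound 1 `Cc1ccc(/C=C2\CCC/C(=C\c3ccccc3[N+](=O)[O-])C2=O)cc1` gives 5.15 and compound 2 `O=C1/C(=C/c2ccc(Cl)cc2)CCC/C1=C\c1cccc([N+](=O)[O-])c1` gives 5.58, the higher of the two numbers, with a gap between them that lies beyond the usual scatter. Compound 3 `Cc1ccc(/C=C2\CCC/C(=C\c3cccc([N+](=O)[O-])c3)C2=O)cc1` has not yet been measured in this assay. It departs from compound 2 by a single change, methyl in place of chloro on an aromatic carbon, para to a large group, so that 4-chlorophenyl becomes 4-methylphenyl. Within the data shown here, no measured pair shows this change alone, so the expectation starts from compound 2 at 5.58 and from the swap itself. The estimated step of a number 0.18 log units lower from compound 2 to compound 3 (within the scatter) is a small fall, expected to lie close to the scatter. For compound 3 the expected value is 5.4, with an estimated range of 5.05 to 5.75.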

Compound 3, partition coefficient: 5.35
Compound 3: middle estimate off by 0.05 log units, on the high side, and the stated range covers the measured number.
By their numbers in this assay, from the lowest: compounds 1, 3 and 2 (each within the scatter of the next, the first and the last beyond it).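

Among these compounds, the swap of chloro for methyl on an aromatic carbon, para to a large group, is read on its own here for the first time: 4-chlorophenyl to 4-methylphenyl comes to a number 0.23 log units lower from compound 2 to compound 3 (within the scatter) in this assay as a single step. With the rest of the molecule unchanged, chloro and methyl at this place cannot be told apart on this read-out. Nothing in hand bears on why the two groups read so alike.

Still open, going by these compounds, is whether other groups at this place, such as an amine, a carboxylic acid or a longer chain, would stay this close to chloro in this assay or move beyond the scatter. Among the compounds shown here, only one pair carries this step, so whether it holds with the nitro group placed as in compound 1 also remains open.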